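Predicting an Isoxazolyl Amide from Three Measured Analogues

The source may hold more compounds than are shown below. What is called first, only, known or untested is meant among the compounds shown, and "the series" means these compounds.

Three compounds sharing one core were measured in an assay on HEK293 cells for agonist activity at transient receptor potential cation channel subfamily M member 8 (Homo sapiens), read by fluorescence and calcium flux, with a stated time of 15 min; on this read-out higher numbers stand for an effect only at larger amounts of compound and lower numbers for an effect already at smaller amounts:

compound 1, `Cc1ccc(OCC(=O)N(CCCO)Cc2cccs2)cc1`: 3000 nM
compound 2, `Cc1ccc(OCC(=O)N(Cc2cccs2)c2ccn[nH]2)cc1`: 0.2 nM
compound 3, `Cc1ccc(OCC(=O)N(Cc2cccs2)C2CC2)cc1`: 8 nM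

Compound 3 stands second of the three in this assay. Its nearest neighbour is reached through a 40-fold higher number from compound 2 to compound 3 (1.60 log units; beyond the scatter), its furthest through a 380-fold lower number from compound 1 to compound 3 (2.57 log units; beyond the scatter), and both gaps lie beyond the scatter.

Compound 4, `Cc1ccc(OCC(=O)N(Cc2cccs2)c2ccon2)cc1`, has not yet been measured. It differs from compound 3 in one place: 1,2-oxazol-3-yl in place of cyclopropyl on an amide-type nitrogen. Going by the values given here, the steps that bear on this change are a 40-fold higher number from compound 2 to compound 3 (1.60 log units; beyond the scatter) and a 380-fold lower number from compound 1 to compound 3 (2.57 log units; beyond the scatter), both large, and together they show that the group on this nitrogen decides the number in this assay; the five-membered aromatic ring of compound 2 gave the lowest number of the three, while the 3-hydroxypropyl chain of compound 1 gave the highest. Compound 4 carries a five-membered aromatic ring on the same nitrogen, though one without a hydrogen-bond donor, and its pattern is closer to compound 2 than to compound 1.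

Among the compounds with values here, a lower number is therefore expected for compound 4, estimated as an 8.0-fold lower number from compound 3 to compound 4 (0.90 log units; beyond the scatter), a smaller move than the one seen with compound 2. Compound 4 is estimated at 1 nM, within 0.2 nM to 8 nM.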

Compound 4, half-maximal effective concentration: 2 nM
Compound 4: middle estimate off by 2.0-fold (0.30 log units), on the low side; measured number inside the range.
By their numbers in this assay, from the lowest: compound 2; then compound 4; then compound 3; then compound 1.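

In this assay, the result shows that a five-membered aromatic ring on this amide-type nitrogen can give a lower number than cyclopropyl even when that ring is 1,2-oxazol-3-yl, which has no hydrogen-bond donors: a 4.0-fold lower number from compound 3 to compound 4 (0.60 log units; beyond the scatter). The two five-membered aromatic rings are not interchangeable, however, since replacing 1H-pyrazol-5-yl with 1,2-oxazol-3-yl gives a 10-fold higher number from compound 2 to compound 4 (1.00 log units; beyond the scatter), so the ring type alone does not set the number. Replacing 3-hydroxypropyl with 1,2-oxazol-3-yl gives a 1500-fold lower number from compound 1 to compound 4 (3.18 log units; beyond the scatter), and among the four compounds both aromatic rings now stand below cyclopropyl, with 3-hydroxypropyl highest.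

Nothing available explains why the two rings differ from each other or from cyclopropyl. The compounds shown also leave open how a phenyl ring, a 1,3-thiazol-2-yl ring or a plain propyl chain on the same nitrogen would compare, and the last of these would show how much of the high number of compound 1 goes with the hydroxyl group rather than the chain.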